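Methyl for methoxy on the coumarin-type core, second ring position

The source may report more compounds than this note shows. Statements on the series, on what has been measured and on what is new or still open speak of the compounds shown alone.

Measured so far:
compound 1 `COc1ccc(/C=C/c2cc(OC)cc(OC)c2/C=C/C(=O)c2cc3cc(OC)ccc3oc2=O)cc1` gives > 60000 nM
compound 2 `COc1ccc(/C=C/c2cc(OC)cc(OC)c2/C=C/C(=O)c2cc3cc(C)ccc3oc2=O)cc1` gives 5090 nM
compound 3 `COc1ccc(/C=C/c2cc(OC)cc(OC)c2/C=C/C(=O)c2cc3ccc(OC)cc3oc2=O)cc1` gives 4200 nM

In an assay on isolated protein for inhibition of Amine oxidase [flavin-containing] B (Homo sapiens), read by fluorescence, with a stated time of 15 min (on this read-out lower numbers stand for stronger inhibition and higher numbers for weaker inhibition), compound 1 reaches only a limit of the assay, (the limit of > 60000 nM in this assay, at which 1 of the 3 values shown sits). The change methyl in place of methoxy on an aromatic carbon then gives an at least 11-fold lower number from compound 1 to compound 2 (1.07 log units; beyond the scatter). Compound 3 sits within the scatter of compound 2, so the two are not told apart here. The difference between the core of compound 3 and the core of compound 1 is not broken down here.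

Compound 4 `COc1ccc(/C=C/c2cc(OC)cc(OC)c2/C=C/C(=O)c2cc3ccc(C)cc3oc2=O)cc1` carries the same change, (methyl in place of methoxy on an aromatic carbon), made at a place worded identically. Because compound 3 already gives 4200 nM, a number rather than a limit, the expected step of a 1.4-fold lower number from compound 3 to compound 4 (0.15 log units; within the scatter) is smaller than the measured one. Compound 4 is estimated at 3000 nM, between 1200 nM and 8000 nM.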

Compound 4, half-maximal inhibitory concentration: 2780 nM
The estimate for compound 4 lay 1.1-fold (0.03 log units) above the measured number; the measured number falls inside the stated range.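

In this assay, methyl in place of methoxy gives a 1.5-fold lower number from compound 3 to compound 4 (0.18 log units; within the scatter), and the two methyl compounds, whose cores differ, show a 1.8-fold lower number from compound 2 to compound 4 (0.26 log units; within the scatter), so neither step separates its pair. The size of the step therefore does not carry over unchanged from one core to the other: the same change on two cores in this assay, an at least 11-fold lower number (1.07 log units; beyond the scatter) from compound 1 to compound 2 and a 1.5-fold lower number (0.18 log units; within the scatter) from compound 3 to compound 4, at least 7.8-fold (0.89 log units) apart, beyond the scatter of two such steps Compound 1 gives > 60000 nM, which is a limit of the assay and not a number, so the full size of the first step stays unknown, and two cores cannot show why the steps differ.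

On these data alone, whether an amine, a carboxylic acid or a longer chain in this place would move the number beyond the scatter remains open. So does the size of this change on any further core.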